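Adding 1-hydroxy-1-methylethyl to compound 2

This account rests on a few compounds, and the source may have more. Where it says the series, first, only, none or still open, it means among the compounds named here.

Compound 1 `CC1=C(CN2CC(C(=O)O)C2)CCc2cc(OCC3Cc4ccccc4C3)ccc21`: > 1 mg/kg, a limit
Compound 2 `COc1cc(C)ccc1COc1ccc2c(c1)CCC(CN1CC(C(=O)O)C1)=C2C`: > 0.1 mg/kg, a limit

In a functional assay on the whole organism (strain BALB/c) with Mus musculus as the target, with a stated time of 4 h (on this read-out lower numbers stand for an effect already at smaller amounts and higher numbers for an effect only at larger amounts of compound), compound 2 gives only a limit, > 0.1 mg/kg, and no number. Compound 3 `COc1cc(CC(C)(C)O)ccc1COc1ccc2c(c1)CCC(CN1CC(C(=O)O)C1)=C2C` places 1-hydroxy-1-methylethyl in place of hydrogen on a saturated chain carbon bound to an aromatic carbon. For the measured compounds named here, the one measured step, a step that the two limits leave unreadable from compound 1 to compound 2, changes a different place and has no readable size, so it offers no size or direction to carry over. The expected step, held only loosely, is a step that the limit leaves unreadable from compound 2 to compound 3. For compound 3 the estimate is 0.3 mg/kg, with an expected range of 0.04 mg/kg to 2 mg/kg.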

Compound 3, dose for half-maximal effect: 0.16 mg/kg
For compound 3 the middle estimate is 1.9-fold (0.27 log units) above the measured one, and the stated range covers the measured number.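

No new step can be read between compound 2 and compound 3: in this assay compound 2 gives only the limit > 0.1 mg/kg and no number. The compounds shown leave open how far 1-hydroxy-1-methylethyl shifts the dose for half-maximal effect, and in which direction.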